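Swapping the Aryl Group on the Amine Nitrogen

The compounds below may be only part of what the source reports. "The series", "measured", "known", "first", "only" and "open" are said of these compounds alone.

Within the data shown here, compound 2 `CC(C)c1ccc(-c2nc(SCc3cn(CC(=O)NC(=O)Nc4ccccn4)nn3)nc(Nc3cccc(C(F)(F)F)c3)c2C#N)cc1` has been tested in a functional assay on MCF7 cells (Homo sapiens) for inhibition, read by MTT assay, with a stated time of 72 h (a lower number here means a stronger inhibitor, a higher number a weaker inhibitor), and gives 8620 nM, the only numerical value among the two compounds measured so far. Compound 1 `CC(C)c1ccc(-c2nc(SCc3cn(CC(=O)NC(=O)Nc4ccccn4)nn3)nc(Nc3ccc(Cl)cc3)c2C#N)cc1` reaches only a limit in this assay, > 64000 nM. Among the measured compounds shown here, the single measured step, an at least 7.4-fold lower number from compound 1 to compound 2 (0.87 log units; beyond the scatter), shows that the group on this nitrogen can shift the read-out considerably. Compound 3 `CC(C)c1ccc(Nc2nc(SCc3cn(CC(=O)NC(=O)Nc4ccccn4)nn3)nc(-c3ccc(C(C)C)cc3)c2C#N)cc1` differs from compound 2 by 4-isopropylphenyl in place of 3-(trifluoromethyl)phenyl on a nitrogen on an aromatic ring. For the measured compounds named here, no measured step covers this incoming group, so the direction stays open. Compound 3 is therefore expected to land near 20000 nM, within a wide range from 4000 nM to 64000 nM. That expected change amounts to a 2.3-fold higher number from compound 2 to compound 3 (0.37 log units; beyond the scatter).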

Compound 3, half-maximal inhibitory concentration: 28600 nM
The estimate for compound 3 lay 1.4-fold (0.16 log units) below the measured number; low and high end bracket the measured number.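

In this assay, the 4-isopropylphenyl group on this nitrogen gives a weaker result than 3-(trifluoromethyl)phenyl (a 3.3-fold higher number from compound 2 to compound 3 (0.52 log units; beyond the scatter)) but a stronger one than 4-chlorophenyl (an at least 2.2-fold lower number from compound 1 to compound 3 (0.34 log units; beyond the scatter)). Three different aryl groups at this position therefore give three separate results, with compound 3 in the middle. For compound 1 the value is a limit of the assay, so the second step gives only a minimum size: the limit of > 64000 nM in this assay, at which 1 of the 3 values shown sits.

On these data alone, how a plain phenyl, or an aryl ring carrying an amine or a carboxylic acid, would behave on this nitrogen remains open.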